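Swapping a phenyl group where only limits are known

The source may report more compounds than this note shows. Statements on the series, on what has been measured and on what is new or still open speak of the compounds shown alone.

Of the compounds shown here, three have been tested in an ADME assay on HepG2 cells (Homo sapiens) for cytotoxicity, with a stated time of 72 h (a higher number here means that more compound is needed for the effect, a lower number that less compound is needed), and none has yet given an actual number. Compound 1 (`COC(=O)C1CCN(c2cc(Cl)c(C(=O)Nc3cc(-c4nc5ccccc5s4)ccc3C)cc2[N+](=O)[O-])CC1`) reads > 25000 nM as a limit of the assay. Compound 2 (`Cc1cc(NC(=O)c2cc([N+](=O)[O-])ccc2Cl)cc(-c2nc3ccccc3s2)c1O`) reads > 25000 nM as a limit too. Compound 3 (`O=C(Nc1cccc(-c2ccccc2)c1)c1cc([N+](=O)[O-])ccc1Cl`) reads > 27000 nM as a limit as well. Compound 3 therefore stands where the other two stand, with no exact value to place it by.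

Compound 4 (`O=C(Nc1cccc(-c2nc3ccccc3[nH]2)c1)c1cc([N+](=O)[O-])ccc1Cl`) differs from compound 3 in one place (1H-benzimidazol-2-yl in place of phenyl on an aromatic carbon) with 1H-benzimidazol-2-yl in place of phenyl on an aromatic carbon. No measured pair among these compounds shows what a single change does in this assay so there is no direct guide to the size of this step. All three tested compounds stop at a limit despite their differing structures, so no change beyond the usual scatter is expected, in either direction. The estimated move is an at least 1.0-fold lower number from compound 3 to compound 4 (0.03 log units; that floor lies within the scatter) and it stays within that scatter. For compound 4 the estimate is 25000 nM with an expected range from 12000 nM to 40000 nM and a reading that is only a limit is the likeliest outcome.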

Compound 4, half-maximal effective concentration: > 27000 nM
Compound 4: only a limit was reported (the forecaster's own chance of this, stated with the estimate: 75%); middle value at least 1.0-fold (0.03 log units) from the limit.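

In this assay compound 4 reads > 27000 nM, which is a limit. Going by these compounds alone, compound 3 reads > 27000 nM, also a limit, so no step from one to the other can be read. Still open is the concentration at which any of these compounds gives the effect, and whether 1H-benzimidazol-2-yl in place of phenyl changes it at all.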